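The compounds below may be only part of what the source reports. "The series", "measured", "known", "first", "only" and "open" are said of these compounds alone.

Measured so far in a functional assay on MCF7 cells (Homo sapiens) for antiproliferative activity, read by MTT assay, with a stated time of 72 h; on this read-out lower numbers stand for stronger inhibition and higher numbers for weaker inhibition:

compound 1, `O=c1cc(CSC(=S)N2CCCC2)oc2cc(Cl)ccc12`, gives > 25000 nM
compound 2, `COc1ccc2occ(CSC(=S)N3CCOCC3)c(=O)c2c1`, gives 11800 nM
compound 3, `O=c1cc(CSC(=S)N2CCOCC2)oc2cc(Cl)ccc12`, gives > 25000 nM

The value of compound 1 is a limit of this assay, not a number. The value of compound 3 is likewise a limit. Compound 2 is the only one of the three with a number in this assay.

Compound 3 and compound 1 share one core and differ in a single place: pyrrolidin-1-yl in place of morpholin-4-yl on a thiocarbonyl carbon. The step that the two limits leave unreadable from compound 3 to compound 1 cannot be read, because both values sit at the limit of > 25000 nM in this assay, at which 2 of the 3 values shown sit.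

Compound 2 carries a different core from compound 3; the difference between the two cores is not broken down here.

Compound 4, `COc1ccc2occ(CSC(=S)N3CCCC3)c(=O)c2c1`, has not yet been measured in this assay. It stands to compound 2 as compound 1 stands to compound 3: pyrrolidin-1-yl in place of morpholin-4-yl on a thiocarbonyl carbon. The place of the change is the same in both pairs, so this is the same change made twice among the compounds shown.

What the change did from compound 3 to compound 1 is not readable, so no size or direction is carried over. The expectation for compound 4 therefore rests on compound 2 alone, at 11800 nM, with the step from compound 2 to compound 4 expected to be about a 1.0-fold higher number from compound 2 to compound 4 (0.01 log units; within the scatter). Compound 4 is accordingly expected to give roughly 12000 nM in this assay, with the expected range from 4000 nM to 28000 nM.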

Compound 4, half-maximal inhibitory concentration: 34100 nM
Beside the measured number, compound 4's estimate is 2.8-fold (0.45 log units) below it; measured number outside the range, above it.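

Notes on the change from morpholin-4-yl to pyrrolidin-1-yl on a thiocarbonyl carbon. In this assay, among the compounds shown here, on the core of compound 2, this change gives a 2.9-fold higher number from compound 2 to compound 4 (0.46 log units; beyond the scatter), a modest move toward weaker inhibition that lies beyond the usual scatter and is the only readable instance of the change. The same change on the core of compound 3 cannot be read, because the values of compound 3 and compound 1 are both limits of the assay, not numbers: the limit of > 25000 nM in this assay, at which 2 of the 4 values shown sit. The pair on the core of compound 2 therefore shows what the change does on that core alone, and the series gives no evidence that its direction or size carries over to the core of compound 3, nor any evidence that it does not.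

Still open, from the compounds shown here alone, is whether piperidin-1-yl or 4-methylpiperazin-1-yl on the same thiocarbonyl carbon would stay close to compound 2 or move toward compound 4 on the core of compound 2. Also open, going by these compounds, is whether any group at that place would bring the core of compound 3 to a readable number, which a second readable step would require.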